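A Third Methoxy Pattern on the Same Phenyl Ring

The source may report more compounds than this note shows. Statements on the series, on what has been measured and on what is new or still open speak of the compounds shown alone.

Measured so far:
compound 1 `COc1ccc(OC)c(/C=C/C(=O)Nc2cc3c(Nc4ccc(F)c(Cl)c4)ncnc3cc2O[C@H]2CCOC2)c1`: 36300 nM
compound 2 `COc1cc(/C=C/C(=O)Nc2cc3c(Nc4ccc(F)c(Cl)c4)ncnc3cc2O[C@H]2CCOC2)cc(OC)c1O`: 30500 nM
compound 3 `COc1cc(/C=C/C(=O)Nc2cc3c(Nc4ccc(F)c(Cl)c4)ncnc3cc2O[C@H]2CCOC2)cc(OC)c1OC`: 28400 nM

In a functional assay on MCF7 cells (Homo sapiens) for cytotoxicity, read by MTT assay, with a stated time of 72 h (a lower number here means a stronger inhibitor, a higher number a weaker inhibitor), compound 1 gives 36300 nM, the highest of the three numbers, but compound 2 and compound 3 both sit within the usual scatter of it. Compound 4 `COc1ccc(/C=C/C(=O)Nc2cc3c(Nc4ccc(F)c(Cl)c4)ncnc3cc2O[C@H]2CCOC2)c(OC)c1OC` differs from compound 1 in one place: 2,3,4-trimethoxyphenyl in place of 2,5-dimethoxyphenyl on a double-bonded chain carbon bound to a double-bonded chain carbon. Two measured steps change exactly this ring, and both stay small: a 1.2-fold lower number from compound 1 to compound 2 (0.08 log units; within the scatter) and a 1.3-fold lower number from compound 1 to compound 3 (0.11 log units; within the scatter). Neither rose above the scatter, so the change to compound 4 is not expected to move the number beyond the scatter either. Compound 4 is therefore expected to give about 30000 nM, with a range from 15000 nM to 60000 nM. The expected step is a 1.2-fold lower number from compound 1 to compound 4 (0.08 log units; within the scatter).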

Compound 4, half-maximal inhibitory concentration: 4650 nM
Beside the measured number, compound 4's estimate is 6.5-fold (0.81 log units) above it; measured number outside the range, below it.
By their numbers in this assay, from the lowest: compound 4; then compounds 3, 2 and 1 (each within the scatter of the next).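

Here this assay records a 7.8-fold lower number from compound 1 to compound 4 (0.89 log units; beyond the scatter) and a 6.6-fold lower number from compound 2 to compound 4 (0.82 log units; beyond the scatter) for changes at this position, the first steps on this ring beyond the scatter. With a 6.1-fold lower number from compound 3 to compound 4 (0.79 log units; beyond the scatter) between two rings that each carry three methoxy groups, the arrangement of those groups matters here, not only their number. Nothing measured here explains why this arrangement gives the lower number. Still open, going by these compounds, is whether 2,3,4-trimethoxyphenyl needs all three methoxy groups, and whether an amine or a carboxylic acid on this ring would keep the lower number.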